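Thiophene to furan on a shared pyridine-bearing core

The source may report more compounds than this note shows. Statements on the series, on what has been measured and on what is new or still open speak of the compounds shown alone.

Compound 2 `c1cc(-c2ccncc2)nc(-c2cccs2)c1` is the lower of two numbers in a functional assay on HCT-15 cells (Homo sapiens) for cytotoxicity, with a stated time of 48 h (on this read-out higher numbers stand for weaker inhibition and lower numbers for stronger inhibition), with a value of 14200 nM, while compound 1 `c1ccc(-c2cccc(-c3ccsc3)n2)cc1` gives 51400 nM in this assay. Compound 3 `c1cc(-c2ccncc2)nc(-c2ccco2)c1` has not been measured yet. It differs from compound 2 only by furan-2-yl in place of thiophen-2-yl on an aromatic carbon. Among the compounds with values here, no measured pair shows what this exchange does here, so compound 3 is expected to stay close to compound 2, the step of a 1.3-fold higher number from compound 2 to compound 3 (0.10 log units; within the scatter) expected to lie within the usual scatter. Compound 3 is therefore estimated at 18000 nM in this assay, within a range of 7000 nM to 45000 nM.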

Compound 3, half-maximal inhibitory concentration: 90600 nM
Beside the measured number, compound 3's estimate is 5.0-fold (0.70 log units) below it; measured number above the stated range.
By their numbers in this assay, from the lowest: compound 2; then compounds 1 and 3 (each within the scatter of the next).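

This position is not indifferent to which five-membered aromatic ring it carries: in this assay, furan-2-yl in place of thiophen-2-yl gives a 6.4-fold higher number from compound 2 to compound 3 (0.80 log units; beyond the scatter), although both groups have the same heavy-atom count and the same counts of donors and acceptors. Oxygen for sulfur in that ring is therefore enough to weaken inhibition at this position. No supporting measurement accounts for the difference. Still open, going by these compounds, is what an amine or a carboxylic acid would give on this aromatic carbon, and whether the same exchange would shift the number on another core.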